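The compounds below may be only part of what the source reports. "The series", "measured", "known", "first", "only" and "open" are said of these compounds alone.

Compound 1, `O=C(Nc1ccc([N+](=O)[O-])cc1)c1cc(Cl)ccc1O`: 12.4 10^-6 cm/s
Compound 2, `O=C(Nc1ccc([N+](=O)[O-])c(Cl)c1)c1cc(Cl)ccc1O`: 12.3 10^-6 cm/s
Compound 3, `O=C(Nc1cccc(Cl)c1)c1cc(Cl)ccc1O`: 8.6 10^-6 cm/s

These three compounds share one core and differ only in the groups on the amide-side ring. In an ADME assay for permeability, using PAMPA, with a stated time of 3 h (on this read-out higher numbers stand for higher permeability and lower numbers for lower permeability), compound 1 gives the top number of the three, yet the step of a 1.0-fold lower number from compound 1 to compound 2 (0.00 log units; within the scatter) and the step of a 1.4-fold lower number from compound 2 to compound 3 (0.16 log units; within the scatter) both lie within the scatter, so all three are effectively level. Compound 4, `O=C(Nc1ccc(C(F)(F)F)cc1)c1cc(Cl)ccc1O`, differs from compound 1 in one place: trifluoromethyl in place of nitro on an aromatic carbon. Going by the values given here, the only measured step that touches the nitro, a 1.4-fold lower number from compound 2 to compound 3 (0.16 log units; within the scatter), was within the scatter, and so was a 1.0-fold lower number from compound 1 to compound 2 (0.00 log units; within the scatter); no measured step brings in a trifluoromethyl. A change within the scatter is therefore expected, and the estimate means a step of a 1.0-fold lower number from compound 1 to compound 4 (0.01 log units; within the scatter). For compound 4 the expected value in this assay is 12 10^-6 cm/s, with a range from 7 10^-6 cm/s to 20 10^-6 cm/s.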

Compound 4, apparent permeability: 6.9 10^-6 cm/s
The estimate for compound 4 lay 1.7-fold (0.24 log units) above the measured number; measured number below the stated range.
By their numbers in this assay, from the lowest: compounds 4, 3, 2 and 1 (each within the scatter of the next).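

In this assay, trifluoromethyl, with 0 hydrogen-bond acceptors, can stand in place of nitro, with 2, on this aromatic carbon para to a large group, and the change stays within the usual scatter: a 1.8-fold lower number from compound 1 to compound 4 (0.25 log units; within the scatter). So at this position, the read-out does not separate these two groups. No measurement shown here offers an explanation for the size of this step.

The compounds shown leave open how an amine or a carboxylic acid at this position would read. They also leave open whether the same exchange would stay within the scatter with a chloro group also on the ring, as in compound 2.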